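Swapping a Sulfamoyl Group for Bromine

This account rests on a few compounds, and the source may have more. Where it says the series, first, only, none or still open, it means among the compounds named here.

Of the compounds shown here, two have been measured in an assay on HeLa cells for inhibition of Indoleamine 2,3-dioxygenase 1 (Homo sapiens), read by spectrophotometry, with a stated time of 24 h; on this read-out higher numbers stand for an effect only at larger amounts of compound and lower numbers for an effect already at smaller amounts. Compound 1 `Cc1cccc(NNS(=O)(=O)c2ccc(C#N)cc2)c1` gives 3400 nM. Compound 2 `CC(=O)Nc1ccc(S(=O)(=O)NNc2ccc(S(N)(=O)=O)cc2)cc1` gives 3120 nM, the lower of the two numbers, though the gap to compound 1 lies within the scatter. Compound 3 `CC(=O)Nc1ccc(S(=O)(=O)NNc2ccc(Br)cc2)cc1` is the untested partner of compound 2; the change is bromo in place of sulfamoyl on an aromatic carbon. Within the data shown here, no measured pair shows this change, so the step from compound 2 to compound 3 is expected to stay within the scatter, a 1.2-fold lower number from compound 2 to compound 3 (0.10 log units; within the scatter), with no clear direction. Compound 3 is therefore estimated at 2500 nM, between 800 nM and 8000 nM.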

Compound 3, half-maximal effective concentration: 85 nM
Estimate against measurement, compound 3: 29-fold (1.47 log units) above; measured number outside the range, below it.
By their numbers in this assay, from the lowest: compound 3; then compounds 2 and 1 (each within the scatter of the next).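

Bromo in place of sulfamoyl brings a 37-fold lower number from compound 2 to compound 3 (1.56 log units; beyond the scatter) in this assay, so the group on this aromatic carbon, para to a large group, can decide the read-out. The two earlier compounds, whose numbers lay within the scatter of each other, gave no sign of this. No evidence here accounts for the size of this step.

Still open, on these data alone, is whether bromo itself matters or mainly the loss of sulfamoyl. Chloro, methoxy or an amine at this position on the same core would help separate the two.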